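Chloro for hydrogen on the core of compound 1

The compounds below may be only part of what the source reports. "The series", "measured", "known", "first", "only" and "open" are said of these compounds alone.

Measured compounds and their values:
Compound 1, `O=c1c(C(=S)Nc2ccccc2)coc2ccccc12`: 63%
Compound 2, `O=c1c(C2N=C(c3ccccc3)SS2)coc2ccc(Cl)cc12`: 62%
Compound 3, `O=c1c(C2N=C(c3ccccc3)SS2)coc2cc(Cl)c(F)cc12`: 76%

All three were run in a functional assay on PC-3 cells (Homo sapiens) for inhibition, read by sulforhodamine B assay, with a stated time of 48 h, tested at 100 uM; on this read-out lower numbers stand for less inhibition of growth and higher numbers for more inhibition of growth at the one concentration tested. Compound 1 stands second highest of the three numbers. Its nearest neighbour is compound 2, whose number is lower by an amount within the usual scatter, so no order between compound 1 and compound 2 can be read from these two values. Compound 3 lies furthest from compound 1, with a number higher by a gap beyond the scatter.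

Compound 4, `O=c1c(C(=S)Nc2ccccc2)coc2cc(Cl)ccc12`, has not been measured in this assay. It differs from compound 1 as follows: chloro in place of hydrogen on an aromatic carbon. Among the compounds with values here, no pair of measured compounds differs in only this one place, so the size of such a step has not been observed; compound 2 and compound 3 carry a different core and their values cannot be read as a step from compound 1.

The step from compound 1 to compound 4 is expected to be small, a number 3 percentage points higher from compound 1 to compound 4 (within the scatter), at most a slight rise and quite possibly within the scatter. For compound 4 the estimate in this assay is 66%, in the range 50% to 80%.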

Compound 4, percent growth inhibition at one concentration: 55%
Beside the measured number, compound 4's estimate is 11 percentage points above it; low and high end bracket the measured number.
By their numbers in this assay, from the lowest: compounds 4, 2 and 1 (each within the scatter of the next); then compound 3.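

In this assay the series now has its first step in one place: chloro in place of hydrogen on an aromatic carbon of the core of compound 1 gives a number 8 percentage points lower from compound 1 to compound 4 (within the scatter), so this read-out separates no effect of chloro at this position from scatter. The step cannot be carried over to compound 2 or compound 3, which carry chloro on a different core. No measurement given here bears on the cause of this result.

Going by these compounds, whether an amine, a methoxy group or a carboxylic acid on this same carbon would give a step beyond the scatter remains open. Also open, on these data alone, is how chloro would read on the other aromatic carbons of the core of compound 1.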